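Aryl ring variation on the imidazole of a benzoxazinone series

A few compounds are considered here, and "the series" means these few. Any claim that something is new, unique, unknown or untested is made for them only; others in the source may bear on it.

Measured so far:
compound 1 `O=C1COc2ccc(-c3[nH]c(-c4ccccc4)nc3-c3ccccc3)cc2N1` — 47.3%
compound 2 `O=C1COc2ccc(-c3[nH]c(-c4ccc(C(F)(F)F)cc4)nc3-c3ccccc3)cc2N1` — 12.1%

Both were run in a functional assay on DLD-1 cells (Homo sapiens) for cytotoxicity, read by colorimetric assay and MTT assay, with a stated time of 3 days, tested at 20 uM; on this read-out lower numbers stand for a stronger effect and higher numbers for a weaker effect at the one concentration tested. Compound 2 stands lowest of the two numbers shown; its nearest neighbour is compound 1, which gives a higher value than compound 2, and the gap a number 35.2 percentage points lower from compound 1 to compound 2 (beyond the scatter) lies beyond the scatter. Compound 3 `O=C1COc2ccc(-c3[nH]c(-c4ccc(Cl)cc4Cl)nc3-c3ccccc3)cc2N1` is not yet measured. It differs from compound 2 by 2,4-dichlorophenyl in place of 4-(trifluoromethyl)phenyl on an aromatic carbon. Within the data shown here, only the step from compound 1 to compound 2 bears on this change, since it alters the same phenyl ring, and it was large. Compound 3 again carries a substituted phenyl ring at that position, so the value of compound 3 is expected to stay nearer compound 2 than compound 1, with a small step of a number 7.9 percentage points higher from compound 2 to compound 3 (within the scatter) that may well fall within the scatter. Compound 3 is estimated at 20%, expected range 5% to 45%.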

Compound 3, a percentage reported as activity, at one concentration (the size of the read-out at that concentration, not a potency): 61.9%
Estimate against measurement, compound 3: 41.9 percentage points below; measured number above the stated range.
By their numbers in this assay, from the lowest: compound 2; then compound 1; then compound 3.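

In this assay, substitution on the phenyl ring at this position, an aromatic carbon between two ring nitrogen atoms, does not by itself lower the number: 2,4-dichlorophenyl in place of phenyl gives a number 14.6 percentage points higher from compound 1 to compound 3 (beyond the scatter), the opposite direction to the step seen with trifluoromethyl. Exchanging 4-(trifluoromethyl)phenyl for 2,4-dichlorophenyl gives a number 49.8 percentage points higher from compound 2 to compound 3 (beyond the scatter), so the outcome depends on which substituents the ring carries, and the two substituted rings lie on opposite sides of the unsubstituted one. Nothing at hand explains why these two rings part so widely.

Compound 2 and compound 3 differ in both the kind and the number of substituents, so these two changes cannot be separated. Going by these compounds, it remains open whether a phenyl ring with a single chlorine, or one carrying an amine or a carboxylic acid, would sit nearer compound 2 or compound 3.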